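Ring Swap and Linker Reversal on a Benzothiophene-Derived Antiproliferative Series

A few compounds are considered here, and "the series" means these few. Any claim that something is new, unique, unknown or untested is made for them only; others in the source may bear on it.

Of the compounds shown here, two have been tested in a functional assay on MCF7 cells (Homo sapiens) for antiproliferative activity, read by CCK-8 assay, with a stated time of 48 h; a higher number here means a weaker inhibitor, a lower number a stronger inhibitor. Compound 1 `O=C(/C=C/CNCCOc1ccc(Oc2c(-c3ccc(F)cc3)sc3cc(O)ccc23)cc1)N1CCCC1` gives 7610 nM. Compound 2 `CN(C)C(=O)/C=C/CN1CC(Oc2ccc(Oc3c(-c4ccc(F)cc4)sc4cc(O)ccc34)cc2)C1` gives 22300 nM, the highest number of the two and beyond the scatter away from compound 1, so compound 2 is the weaker inhibitor of the pair. Compound 3 `O=C(/C=C/CNCCOc1ccc(Oc2c(-c3ccc(F)cc3)sc3cc(O)ccc23)cc1)N1CCC1` has not been measured yet. It differs from compound 2 as follows: 2-((3-((azetidin-1-yl)carbonyl)prop-2-en-1-yl)amino)ethyl in place of 1-(3-(dimethylcarbamoyl)prop-2-en-1-yl)azetidin-3-yl on an oxygen on an aromatic ring. The open amino-ethyl attachment to the aromatic oxygen that compound 3 acquires is also present in compound 1, which differs from compound 3 only in the ring of the amide. Compound 3 is therefore expected to sit nearer to compound 1 than to compound 2, giving an expected step of a 2.5-fold lower number from compound 2 to compound 3 (0.39 log units; beyond the scatter) toward stronger inhibition. The estimate for compound 3 in this assay is 9000 nM, with a range from 3500 nM to 22000 nM.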

Compound 3, half-maximal inhibitory concentration: 7340 nM
The estimate for compound 3 lay 1.2-fold (0.09 log units) above the measured number, within the range that was stated.
By their numbers in this assay, from the lowest: compounds 3 and 1 (each within the scatter of the next); then compound 2.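

In this assay the exchange of azetidin-1-yl in place of pyrrolidin-1-yl on a carbonyl carbon gives a 1.0-fold lower number from compound 1 to compound 3 (0.02 log units; within the scatter), so these two amide rings do not separate the compounds. The change on the oxygen on an aromatic ring, with 2-((3-((azetidin-1-yl)carbonyl)prop-2-en-1-yl)amino)ethyl in place of 1-(3-(dimethylcarbamoyl)prop-2-en-1-yl)azetidin-3-yl, gives a 3.0-fold lower number from compound 2 to compound 3 (0.48 log units; beyond the scatter), which shows that two groups of the same atoms, joined differently, can differ beyond the scatter at this position. Nothing at hand bears on the cause of either step.

As far as these compounds go, the amide end and the link to the oxygen change together in that second step, so the share of each stays open. Also open, from the compounds shown here alone, is how a piperidin-1-yl or morpholin-4-yl group on the carbonyl carbon, or a longer chain on the oxygen, would read in this assay.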